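Removing the hydrazone arm from the aminopyrazolopyridine series

The source may hold more compounds than are shown below. What is called first, only, known or untested is meant among the compounds shown, and "the series" means these compounds.

Compound 1, `CCOC(=O)C1=C(N/C=N/c2ccccn2)Nc2[nH]nc(C)c2C1c1ccc(N(C)C)cc1`: 26200 nM
Compound 2, `CCOC(=O)C1=C(NN=C(C#N)C#N)Nc2[nH]nc(C)c2C1c1ccc(N(C)C)cc1`: 13700 nM
Compound 3, `CCOC(=O)C1=C(N/N=C(/C(C)=O)C(=O)OCC)Nc2[nH]nc(C)c2C1c1ccc(N(C)C)cc1`: > 100000 nM

Three compounds sharing one core were tested in a functional assay on HepG2 cells (Homo sapiens) for inhibition, read by MTT assay, with a stated time of 48 h; a higher number here means a weaker inhibitor, a lower number a stronger inhibitor. Compound 1 gives 26200 nM, and compound 2 gives 13700 nM; the step of a 1.9-fold lower number from compound 1 to compound 2 (0.28 log units; within the scatter). Compound 3 reached only a limit of the assay, > 100000 nM, so for compound 3 no number is known, and it stands at the limit of > 100000 nM in this assay, at which 1 of the 3 values shown sits.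

Compound 4, `CCOC(=O)C1=C(N)Nc2[nH]nc(C)c2C1c1ccc(N(C)C)cc1`, is the compound still to be measured. It differs from compound 3 in one place: a hydrogen atom in place of a group of 10 heavy atoms (6 carbon, 1 nitrogen, 3 oxygen; no ring), on an amine nitrogen.

Among the compounds with values here, two measured steps bear on this change, since both end in the same group entering on that amine nitrogen: an at least 3.8-fold higher number from compound 1 to compound 3 (0.58 log units; beyond the scatter) and an at least 7.2-fold higher number from compound 2 to compound 3 (0.86 log units; beyond the scatter). Both went to a higher number when this group came in, and removal of the same group points the other way. Compound 4 is therefore expected to give a lower number than the limit of compound 3, with the step estimated as an at least 2.5-fold lower number from compound 3 to compound 4 (0.39 log units; beyond the scatter). On that basis compound 4 is estimated at 40000 nM, with a range from 10000 nM to 150000 nM.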

Compound 4, half-maximal inhibitory concentration: 4240 nM
Beside the measured number, compound 4's estimate is 9.4-fold (0.97 log units) above it; the whole stated range lies above it.
By their numbers in this assay, from the lowest: compound 4; then compounds 2 and 1 (each within the scatter of the next). At a limit, above all of these: compound 3.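

In this assay, putting a hydrogen atom on the amine nitrogen in place of each of the three larger groups gives an at least 23-fold lower number from compound 3 to compound 4 (1.37 log units; beyond the scatter), a 3.2-fold lower number from compound 2 to compound 4 (0.51 log units; beyond the scatter) and a 6.2-fold lower number from compound 1 to compound 4 (0.79 log units; beyond the scatter). The earlier compounds compared only one large group with another on this nitrogen, whereas the free amine now shows that every group shown, with or without a ring, gives a higher number than hydrogen, each step beyond the scatter. The value of compound 3 is a limit of the assay and not a number: the limit of > 100000 nM in this assay, at which 1 of the 4 values shown sits.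

The compounds shown leave open whether a small group on this amine nitrogen, such as a methyl or an acetyl group, would stay close to the free amine or move towards the larger groups. Nothing shown separates the size of the group that leaves from its other features, so the series does not tell which of them sets the number.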